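A nitro isomer of compound 2

This account rests on a few compounds, and the source may have more. Where it says the series, first, only, none or still open, it means among the compounds named here.

Values in a toxicity assay on HeLa cells (Homo sapiens) for cytotoxicity, read by MTT assay, with a stated time of 24 h; on this read-out lower numbers stand for stronger inhibition and higher numbers for weaker inhibition:
- compound 1 `Cc1ncc([N+](=O)[O-])n1CC(O)CSC(=S)N1CCN(c2ccccc2)CC1` gives > 5000000 nM (a limit of the assay)
- compound 2 `Cc1ncc([N+](=O)[O-])n1CC(O)CSC(=S)N1CCN(c2cccc(Cl)c2Cl)CC1` gives 1000000 nM
- compound 3 `Cc1ncc([N+](=O)[O-])n1CC(O)CSC(=S)N1CCN(C(=O)OC(C)(C)C)CC1` gives 689000 nM

Compound 1 stands at > 5000000 nM and this is a limit, not a number. Among the measured compounds shown here, compound 2 gives 1000000 nM in this assay and the only other true number, for compound 3, is 689000 nM so the two sit together, with a 1.5-fold lower number from compound 2 to compound 3 (0.16 log units; within the scatter) between them.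

Compound 4 `Cc1nc([N+](=O)[O-])cn1CC(O)CSC(=S)N1CCN(c2cccc(Cl)c2Cl)CC1` differs from compound 2 by one change 2-methyl-4-nitro-1H-imidazol-1-yl in place of 2-methyl-5-nitro-1H-imidazol-1-yl on a saturated chain carbon, two bonds along the chain from an oxygen on a saturated carbon in which 2-methyl-4-nitro-1H-imidazol-1-yl takes the place of 2-methyl-5-nitro-1H-imidazol-1-yl on a saturated chain carbon, two bonds along the chain from an oxygen on a saturated carbon.

For the measured compounds named here, no measured step touches that group. All three change the group on an amine nitrogen in a ring: an at least 5.0-fold lower number from compound 1 to compound 2 (0.69 log units; beyond the scatter) and an at least 7.2-fold lower number from compound 1 to compound 3 (0.86 log units; beyond the scatter) lie beyond the scatter, while a 1.5-fold lower number from compound 2 to compound 3 (0.16 log units; within the scatter) lies within it. They give no size for the new change, so the expectation starts from compound 2 at 1000000 nM and assumes no shift beyond the scatter. The expected step is a 1.1-fold lower number from compound 2 to compound 4 (0.05 log units; within the scatter) in this assay and it carries a wide margin. For compound 4 the estimated value is 900000 nM with an expected range from 300000 nM to 3000000 nM in this assay for now.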

Compound 4, half-maximal inhibitory concentration: 724000 nM
Compound 4: middle estimate off by 1.2-fold (0.09 log units), on the high side, within the range that was stated.
By their numbers in this assay, from the lowest: compounds 3, 4 and 2 (each within the scatter of the next). At a limit, above all of these: compound 1.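

In this assay, among the compounds shown here, this is the first step that touches the nitroimidazole group rather than the group on the amine nitrogen in the ring: 2-methyl-4-nitro-1H-imidazol-1-yl in place of 2-methyl-5-nitro-1H-imidazol-1-yl on a saturated chain carbon gives a 1.4-fold lower number from compound 2 to compound 4 (0.14 log units; within the scatter). The two groups have the same atoms, joined differently, and with the 2,3-dichlorophenyl group held constant this read-out does not separate the two nitro isomers. The reading rests on this one pair and offers no comparison with compound 1, which remains a limit rather than a number: the limit of > 5000000 nM in this assay, at which 1 of the 4 values shown sits.

The compounds shown leave open whether the two nitro isomers would also match with phenyl or tert-butoxycarbonyl on the amine nitrogen in the ring. They also leave open how this assay would respond if an amine or a nitrile took the place of the nitro group, or if a longer chain linked the 2-methyl-4-nitro-1H-imidazol-1-yl group to the rest of the molecule.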